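The compounds below may be only part of what the source reports. "The series", "measured", "known", "first", "only" and "open" are said of these compounds alone.

Measured so far in an ADME assay on Vero cells (Chlorocebus sabaeus) for cytotoxicity; on this read-out lower numbers stand for higher toxicity in this test and higher numbers for lower toxicity in this test:

Compound 1, `CC(c1cc(F)cc(F)c1)N1CC2(CCN(c3nc(=O)c4cc(C(F)(F)F)cc([N+](=O)[O-])c4s3)CC2)C1`, gives > 64 ug/mL, which is a limit of the test and not a number.
Compound 2, `CC(c1ccc(Cl)c(F)c1)N1CC2(CCN(c3nc(=O)c4cc(C(F)(F)F)cc([N+](=O)[O-])c4s3)CC2)C1`, gives > 64 ug/mL, again a limit of the test.

Going by the values given here, compound 2 therefore stands at the edge of what this assay can report, and the one further value shown is likewise a limit. Among the compounds with values here, the only measured step, a step that the two limits leave unreadable from compound 1 to compound 2, cannot be read, since both of its ends are limits. The evidence is summed up in the limit of > 64 ug/mL in this assay, at which 2 of the 2 values shown sit.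

Compound 3, `O=c1nc(N2CCC3(CC2)CN(Cc2ccc(C(F)(F)F)cc2)C3)sc2c([N+](=O)[O-])cc(C(F)(F)F)cc12`, differs from compound 2 by 4-(trifluoromethyl)benzyl in place of 1-(4-chloro-3-fluorophenyl)ethyl on an amine nitrogen in a ring. No measured step concerns this change, and the single step that exists is unreadable, so nothing shown points to a step in either direction beyond the usual scatter. The step from compound 2 to compound 3 is thus expected to be a step that the limit leaves unreadable from compound 2 to compound 3, with the outcome most likely again a limit. Compound 3 is estimated at 80 ug/mL in this assay, within a range from 32 ug/mL to 200 ug/mL.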

Compound 3, half-maximal cytotoxic concentration: > 64 ug/mL
Compound 3 gave a limit, no number (the forecaster's own chance of this, stated with the estimate: 70%); the middle value lies beyond the limit too.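

In this assay compound 3 gives > 64 ug/mL which is a limit of the test and not a number, so none of the steps among compound 1, compound 2 and compound 3 can be read. Still open is where each compound's true value lies and whether these changes of group alter it, as all values shown sit at one edge: the limit of > 64 ug/mL in this assay, at which 3 of the 3 values shown sit.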